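The source may report more compounds than this note shows. Statements on the series, on what has been measured and on what is new or still open speak of the compounds shown alone.

Measured in a functional assay on MGC-803 cells (Homo sapiens) for inhibition, read by MTT assay, with a stated time of 72 h; a higher number here means a weaker inhibitor, a lower number a stronger inhibitor:
compound 1 `CN1CCN(c2cc(C(F)(F)F)nc(SCc3ccc(C(F)(F)F)cc3)n2)CC1`: 15800 nM
compound 2 `CC(C)(C)OC(=O)N1CCN(c2cc(C(F)(F)F)nc(SCc3ccc(C(F)(F)F)cc3)n2)CC1`: 22200 nM

Compound 1 holds the lower of the two numbers, but the gap lies within the scatter: a 1.4-fold higher number from compound 1 to compound 2 (0.15 log units; within the scatter). Compound 3 `Cc1csc(Sc2cc(C(F)(F)F)nc(SCc3ccc(C(F)(F)F)cc3)n2)n1` is still unmeasured and carries (4-methyl-1,3-thiazol-2-yl)sulfanyl in place of 4-methylpiperazin-1-yl on an aromatic carbon. Among the measured compounds shown here, the only measured step changes a group on an amine nitrogen in a ring, not the group on the aromatic carbon, so it gives weak guidance here. For the measured compounds named here, no measured step covers this replacement, and no clear direction can be drawn. The expected change is a 1.1-fold lower number from compound 1 to compound 3 (0.05 log units; within the scatter), with no shift expected beyond the scatter, though with wide uncertainty. For compound 3 the estimate is 14000 nM, with an expected range of 4000 nM to 45000 nM.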

Compound 3, half-maximal inhibitory concentration: 21300 nM
Beside the measured number, compound 3's estimate is 1.5-fold (0.18 log units) below it, within the range that was stated.
By their numbers in this assay, from the lowest: compounds 1, 3 and 2 (each within the scatter of the next).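

In this assay, among the compounds shown here, the change at this aromatic carbon gives a 1.3-fold higher number from compound 1 to compound 3 (0.13 log units; within the scatter), the first reading of this position. The position takes either 4-methylpiperazin-1-yl or (4-methyl-1,3-thiazol-2-yl)sulfanyl, a non-aromatic six-membered ring or an aromatic five-membered ring, without a shift beyond the scatter. No supporting data bear on why the two groups read alike.

Going by these compounds, whether an amine with a free hydrogen, a carboxylic acid or a longer alkyl chain here would move the number beyond the scatter stays open. So does the contribution of the 4-(trifluoromethyl)benzyl group.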